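Compound 3 to compound 4: cyano to aminomethyl

The source may hold more compounds than are shown below. What is called first, only, known or untested is meant among the compounds shown, and "the series" means these compounds.

Values in a functional assay on SMMC-7721 cells (Homo sapiens) for inhibition, read by MTT assay, with a stated time of 48 h; a higher number here means a weaker inhibitor, a lower number a stronger inhibitor:
- compound 1 `CN(c1ncccc1CNc1nc(Nc2ccc3c(c2)CC(=O)N3)nc2[nH]cc(Cl)c12)S(C)(=O)=O`: 21900 nM
- compound 2 `CN(c1ncccc1CNc1nc(Nc2ccc(F)cc2)nc2[nH]cc(F)c12)S(C)(=O)=O`: 27900 nM
- compound 3 `CN(c1ncccc1CNc1nc(Nc2cccc(C#N)c2)nc2[nH]cc(F)c12)S(C)(=O)=O`: > 100000 nM, a limit and not a number

Compound 3 stands at the limit of > 100000 nM in this assay, at which 1 of the 3 values shown sits.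

Compound 4 `CN(c1ncccc1CNc1nc(Nc2cccc(CN)c2)nc2[nH]cc(F)c12)S(C)(=O)=O` carries aminomethyl in place of cyano on an aromatic carbon. Within the data shown here, one measured step bears on this change: an at least 3.5-fold higher number from compound 2 to compound 3 (0.55 log units; beyond the scatter), with 3-cyanophenyl entering for 4-fluorophenyl. Among the measured compounds shown here, no measured compound carries aminomethyl. With the cyano gone, a partial move back toward compound 2 at 27900 nM is expected, which means a lower number in this assay. The expected step is an at least 2.2-fold lower number from compound 3 to compound 4 (0.34 log units; beyond the scatter). Compound 4 is estimated at 45000 nM, with an expected range of 12000 nM to 130000 nM.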

Compound 4, half-maximal inhibitory concentration: > 100000 nM
Compound 4: no number, only a limit; the forecaster's own chance of this, stated with the estimate: 35%; middle value at least 2.2-fold (0.34 log units) away from the limit.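

In this assay compound 4 gives > 100000 nM, a limit and not a number. With 3-(aminomethyl)phenyl, an at least 3.5-fold higher number from compound 2 to compound 4 (0.55 log units; beyond the scatter) is seen, so at this position a loss against 4-fluorophenyl is not confined to the nitrile. No order between cyano and aminomethyl can be read, because both compounds sit at the limit: the limit of > 100000 nM in this assay, at which 2 of the 4 values shown sit.

Still open, going by these compounds, is whether the loss follows the group or its place on the phenyl ring, since compound 2 differs from compound 3 and compound 4 in both. A 3-fluorophenyl or a 4-(aminomethyl)phenyl would separate the two.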